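The compounds below may be only part of what the source reports. "The series", "measured", "known", "first", "only" and "open" are said of these compounds alone.

Three compounds share one core and differ only in what sits on the amine nitrogen in a ring. Compound 1 `NC(=O)c1c(NC(=O)c2ccccc2Cl)sc2c1CCNC2` carries hydrogen there; in a functional assay on MKN-74 cells (Homo sapiens) for antiproliferative activity, with a stated time of 24 h (on this read-out lower numbers stand for stronger inhibition and higher numbers for weaker inhibition), compound 1 gives 28700 nM. Compound 2 `NC(=O)c1c(NC(=O)c2ccccc2Cl)sc2c1CCN(Cc1c(Cl)cccc1Cl)C2` carries a 2,6-dichlorobenzyl group, and in this assay compound 2 gives 4740 nM, a step of a 6.1-fold lower number from compound 1 to compound 2 (0.78 log units; beyond the scatter). Compound 3 `NC(=O)c1c(NC(=O)c2ccccc2Cl)sc2c1CCN(C(=S)Nc1ccccc1F)C2` carries a thiourea with a (2-fluorophenyl)amino group; in this assay compound 3 gives 12600 nM, the second highest of the three numbers, with a 2.3-fold lower number from compound 1 to compound 3 (0.36 log units; beyond the scatter) and a 2.7-fold higher number from compound 2 to compound 3 (0.42 log units; beyond the scatter). Compound 4 `NC(=O)c1c(NC(=O)c2ccccc2Cl)sc2c1CCN(C(=S)Nc1ccccc1Br)C2` differs from compound 3 in one place: bromo in place of fluoro on an aromatic carbon. For the measured compounds named here, none of the measured steps swaps one halogen for another; the two steps involving compound 3 exchange the whole group on the ring nitrogen and so say nothing about this smaller change. The expectation is therefore a step of no clear direction, a 1.1-fold lower number from compound 3 to compound 4 (0.02 log units; within the scatter), within the scatter. Compound 4 is estimated at 12000 nM, with a range from 5000 nM to 30000 nM.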

Compound 4, half-maximal inhibitory concentration: 10800 nM
Compound 4: the middle estimate sits 1.1-fold (0.05 log units) above what was measured; the measured number falls inside the stated range.
By their numbers in this assay, from the lowest: compound 2; then compounds 4 and 3 (each within the scatter of the next); then compound 1.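

In this assay, swapping fluoro for bromo on an aromatic carbon, ortho to a large group, gives a 1.2-fold lower number from compound 3 to compound 4 (0.07 log units; within the scatter) and so leaves the read-out of this thiourea unchanged within the scatter. The bromo thiourea also keeps the place the fluoro thiourea held among the groups on the ring nitrogen, with a 2.7-fold lower number from compound 1 to compound 4 (0.42 log units; beyond the scatter) against the bare nitrogen and a 2.3-fold higher number from compound 2 to compound 4 (0.36 log units; beyond the scatter) against the 2,6-dichlorobenzyl group. No evidence is available to explain why this halogen swap leaves the number so little moved. The compounds shown leave open what a methoxy group or an amine would do at this place on the ring. They also leave open whether bromo would behave the same way on another carbon of that ring.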